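The source may report more compounds than this note shows. Statements on the series, on what has been measured and on what is new or still open speak of the compounds shown alone.

In a functional assay on HOS-TE85 cells (Homo sapiens) for inhibition, read by CCK-8 assay, with a stated time of 72 h (a higher number here means a weaker inhibitor, a lower number a stronger inhibitor), compound 1 `O=C(NCCCCn1cccn1)c1cccc(C2SCC(=O)N2c2ccccn2)c1` gives 60.3 nM. Its close relative, compound 2 `O=C(NCCCCc1ccccc1)c1cccc(C2SCC(=O)N2c2ccccn2)c1`, gives 19.7 nM, so compound 1 holds the higher of these two exact numbers. The gap between them is a 3.1-fold lower number from compound 1 to compound 2 (0.49 log units; beyond the scatter). Compound 3 `COc1cccc(OC)c1N1C(=O)CSC1c1cccc(C(=O)NCCCCc2ccccc2)c1` is recorded as > 1000 nM, which is a limit of the assay and not a number.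

Compound 4 `O=C(NCCCCn1cccn1)c1cccc(C2SCC(=O)N2c2ccncc2)c1` has not yet been measured. It differs from compound 1 in one place: pyridin-4-yl in place of pyridin-2-yl on an amide-type nitrogen in a ring. Here pyridin-4-yl stands in place of pyridin-2-yl on an amide-type nitrogen in a ring, so the two compounds have the same atoms, joined differently.

Within the data shown here, only one measured step touches this place: an at least 50-fold higher number from compound 2 to compound 3 (1.70 log units; beyond the scatter), where 2,6-dimethoxyphenyl replaced pyridin-2-yl. That large step shows that the number can respond strongly to the group held here. The modest step of a 3.1-fold lower number from compound 1 to compound 2 (0.49 log units; beyond the scatter) concerns the saturated chain instead and says little about this change. Among the measured compounds shown here, exchanging one pyridine-based group for another is a much smaller edit than the one that gave compound 3, and no measured compound carries pyridin-4-yl. A moderate move towards a higher number therefore seems the likeliest outcome, with wide uncertainty. The expected step is a 2.0-fold higher number from compound 1 to compound 4 (0.30 log units; within the scatter). For compound 4, the estimated value is 120 nM, with an expected range from 30 nM to 500 nM.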

Compound 4, half-maximal inhibitory concentration: > 1000 nM
Compound 4: a limit, no number; the forecaster's own chance of this, stated with the estimate: 8%; middle value at least 8.3-fold (0.92 log units) from the limit.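

Swapping pyridin-2-yl for pyridin-4-yl, an edit that keeps every atom and only joins them differently, gives an at least 16-fold higher number from compound 1 to compound 4 (1.21 log units; beyond the scatter) in this assay. Before this, the only measured step at this place was an at least 50-fold higher number from compound 2 to compound 3 (1.70 log units; beyond the scatter), which replaced pyridin-2-yl with the quite different 2,6-dimethoxyphenyl, so the new step shows that a large change in the number does not need a new set of atoms in the group on the amide-type nitrogen. Compound 4 stands at a limit of the assay and not at a number, so only the smallest possible size of this step is known: the limit of > 1000 nM in this assay, at which 2 of the 4 values shown sit.

Going by these compounds, it remains open whether pyridin-3-yl or a plain phenyl at this place would keep the number close to that of compound 1 or would also reach the limit. On these data alone, it is also open whether pyridin-4-yl has the same effect when the saturated chain carries phenyl, as in compound 2, instead of 1H-pyrazol-1-yl.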